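The source may report more compounds than this note shows. Statements on the series, on what has been measured and on what is new or still open speak of the compounds shown alone.

Compound 3 `CC1CCC(C(=O)N2CC(c3nc(-c4cccc(Cl)c4)no3)C2)CC1` was examined in an assay on HEK293 cells for negative allosteric modulation of metabotropic glutamate receptor 5 (Homo sapiens), read by FLIPR; on this read-out higher numbers stand for weaker inhibition and lower numbers for stronger inhibition. In this assay compound 3 gives only the limit > 10000 nM, not a number. Compound 2 `CC1CCCC(C(=O)N2CC(c3nc(-c4cccc(Cl)c4)no3)C2)C1` likewise gives only the limit > 10000 nM in this assay. Compound 1 `O=C(c1ccc(Cl)cc1)N1CC(c2nc(-c3cccc(F)c3)no2)C1`, too, gives only the limit > 10000 nM in this assay. Going by the values given here, the single step between measured compounds that differ in one place, a step that the two limits leave unreadable from compound 2 to compound 3, cannot be read, because of the limit of > 10000 nM in this assay, at which 3 of the 3 values shown sit. Compound 3 therefore stands at the limit of this assay together with the two other values shown, and nothing separates the three from one another.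

Compound 4 `O=C(N1CCC(F)CC1)N1CC(c2nc(-c3cccc(Cl)c3)no2)C1` differs from compound 3 by 4-fluoropiperidin-1-yl in place of 4-methylcyclohexyl on a carbonyl carbon. Among the compounds with values here, no measured step touches this change, and the one step that has been measured is unreadable, so there is no footing for expecting a gain. The three limits make it most likely that compound 4 will also sit at the limit of this assay. The step is expected to be a step that the limit leaves unreadable from compound 3 to compound 4, that is, none beyond the scatter. Compound 4 is accordingly estimated at 12000 nM in this assay, with a range from 3000 nM to 40000 nM, and the result is most probably reported as a limit rather than as a number.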

Compound 4, half-maximal inhibitory concentration: > 10000 nM
Compound 4 ended at the assay's limit; the forecaster's own chance of this, stated with the estimate: 75%; the middle value lies beyond the limit too.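

The steps to compound 4 from compound 2 and from compound 3 cannot be read, because neither side of either step carries a number: the limit of > 10000 nM in this assay, at which 4 of the 4 values shown sit.

The compounds shown leave open whether any group on the carbonyl carbon gives a measurable value in this assay, and how the four compounds truly compare with one another.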